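Shifting a Methylbenzimidazole Attachment Point on a Shared Core

A few compounds are considered here, and "the series" means these few. Any claim that something is new, unique, unknown or untested is made for them only; others in the source may bear on it.

Compound 1 `Cn1ncc2cc(-c3cnc4[nH]cnc4c3N3CCC4(CCNC4=O)CC3)ccc21` in an assay on cells for binding affinity to Cyclin-C/Cyclin-dependent kinase 19 (Homo sapiens), read by LanthaScreen (on this read-out higher numbers stand for weaker inhibition and lower numbers for stronger inhibition), gives 5 nM.
Compound 2 `O=C1NCCC12CCN(c1c(-c3ccc4scnc4c3)cnc3[nH]ccc13)CC2` in this assay gives 14 nM.
Compound 3 `Cn1cnc2ccc(-c3cnc4[nH]ccc4c3N3CCC4(CCNC4=O)CC3)cc21` in this assay gives 11 nM.

Compound 3 stands second highest of the three numbers in this assay. The nearest number is that of compound 2: a 1.3-fold lower number from compound 2 to compound 3 (0.10 log units; within the scatter), so no order can be read between those two. Compound 1 shows a lower number than compound 3, and that gap lies beyond the scatter; compound 1, however, differs from compound 3 in more than one place, so no single step accounts for it.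

Compound 4 `Cn1cnc2cc(-c3cnc4[nH]ccc4c3N3CCC4(CCNC4=O)CC3)ccc21` differs from compound 3 by 1-methyl-1H-benzimidazol-5-yl in place of 1-methyl-1H-benzimidazol-6-yl on an aromatic carbon. For the measured compounds named here, the only measured step at that position, a 1.3-fold lower number from compound 2 to compound 3 (0.10 log units; within the scatter), exchanged one bicyclic aromatic group for another and stayed within the scatter. Going by the values given here, no measured pair shows what moving the attachment point within the same group does, so the direction is open. Compound 4 is expected to show a 1.1-fold lower number from compound 3 to compound 4 (0.04 log units; within the scatter), a step that would stay within the scatter. Compound 4 is estimated at 10 nM in this assay, with a range from 4 nM to 25 nM.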

Compound 4, half-maximal inhibitory concentration: 50 nM
Compound 4: the middle estimate sits 5.0-fold (0.70 log units) below what was measured; the whole stated range lies below it.
By their numbers in this assay, from the lowest: compound 1; then compounds 3 and 2 (each within the scatter of the next); then compound 4.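

At this position, ortho to a large group, the earlier compounds had shown only an exchange of one bicyclic aromatic group for another that stayed within the scatter. In this assay, moving the attachment point within the same group has a measurable effect, with a 4.5-fold higher number from compound 3 to compound 4 (0.66 log units; beyond the scatter) for an exchange that leaves the heavy atoms, the ring types and the counted hydrogen-bond donors and acceptors unchanged. The 1-methyl-1H-benzimidazol-5-yl group also separates from the 1,3-benzothiazol-5-yl group, with a 3.6-fold higher number from compound 2 to compound 4 (0.55 log units; beyond the scatter), whereas the 1-methyl-1H-benzimidazol-6-yl and 1,3-benzothiazol-5-yl groups of compound 3 and compound 2 cannot be ordered; no evidence at hand explains why the attachment point matters.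

The compounds shown leave open whether the same shift would appear on the core of compound 1, which differs from compound 3 in more than one place. They also leave open how a 1-methyl-1H-benzimidazol-4-yl group would compare at this position, and whether a methoxy group or a dimethylamino group on the benzimidazole would change the number for compound 4.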